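The compounds below may be only part of what the source reports. "The series", "measured", "known", "first", "only" and "open" are said of these compounds alone.

In an ADME assay on CHO cells (Cricetulus griseus) for cytotoxicity, read by MTT assay, with a stated time of 24 h (a higher number here means that more compound is tolerated, a lower number that less compound is tolerated), compound 1 `CC1Cn2cc([N+](=O)[O-])nc2O1` gives > 500000 nM, which is a limit. Compound 2 `CC1Cn2c(nc([N+](=O)[O-])c2-c2ccccc2)O1` gives > 500000 nM, also a limit, so a step that the two limits leave unreadable from compound 1 to compound 2 tells little. Compound 3 `CC1Cn2c(nc([N+](=O)[O-])c2C#CC2CC2)O1`, at 6450 nM, is the only one of the three with a true number. The measured steps into it are both large: an at least 77-fold lower number from compound 1 to compound 3 (1.88 log units; beyond the scatter) and an at least 77-fold lower number from compound 2 to compound 3 (1.88 log units; beyond the scatter). Compound 4 `CC1Cn2c(nc([N+](=O)[O-])c2C#Cc2ccccc2)O1` differs from compound 3 by phenyl in place of cyclopropyl on a triple-bonded carbon. Among the compounds with values here, compound 4 keeps the 2-cyclopropylethynyl step's triple bond, and no measured step makes this exact swap, so no large change is expected. The expected result is a 1.4-fold higher number from compound 3 to compound 4 (0.14 log units; within the scatter), which would not go beyond the scatter. Compound 4 is estimated at 9000 nM, within a range of 2500 nM to 50000 nM.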

Compound 4, half-maximal cytotoxic concentration: 3540 nM
Compound 4: the middle estimate sits 2.5-fold (0.41 log units) above what was measured, and the stated range covers the measured number.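

Phenyl in place of cyclopropyl on a triple-bonded carbon gives a 1.8-fold lower number from compound 3 to compound 4 (0.26 log units; within the scatter) in this assay and so shows that, at this place, a six-membered aromatic ring and a three-membered non-aromatic ring read alike. Compound 4 is thus a second true number among these compounds, and the group on the triple bond can change without a step beyond the scatter. Nothing shown here accounts for this result. From the compounds shown here alone, whether an amine, a carboxylic acid or a longer chain on the same triple-bonded carbon would read alike stays open. So does the outcome of a saturated chain in place of the triple bond.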